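This account rests on a few compounds, and the source may have more. Where it says the series, first, only, none or still open, it means among the compounds named here.

Among the measured compounds shown here, compound 3 `CO[C@H]1C[C@H](O[Si](C)(C)C(C)(C)C)O[C@@H](C)/C1=C/CN1CCNCC1` gives 0.002 ug/mL in a functional assay on the whole organism for inhibition, with Artemia salina as the target (a higher number here means a weaker inhibitor of growth, a lower number a stronger inhibitor of growth), the lowest of the three numbers measured so far. Compound 1 `CO[C@H]1C[C@H](O[Si](C)(C)C(C)(C)C)O[C@@H](C)/C1=C/CO` gives 0.01 ug/mL, and compound 2 `CO[C@H]1C[C@H](O[Si](C)(C)C(C)(C)C)O[C@@H](C)/C1=C/C=O` gives 0.01 ug/mL; no change at the digits printed from compound 1 to compound 2 (within the scatter), so these two stand together. The steps leading to compound 3 were a number 2.3 two-fold dilutions lower from compound 1 to compound 3 (beyond the scatter) and a number 2.3 two-fold dilutions lower from compound 2 to compound 3 (beyond the scatter). Compound 4 `CO[C@H]1C[C@H](O[Si](C)(C)C(C)(C)C)O[C@@H](C)/C1=C/CN1CCCCC1` differs from compound 3 in one place: piperidin-1-yl in place of piperazin-1-yl on a saturated chain carbon bound to a double-bonded chain carbon. For the measured compounds named here, none of the measured steps exchanges one ring for another; the two that touch this position show only that piperazin-1-yl gave a modestly lower number than hydroxy or formyl, and they say nothing about whether the hydrogen-bond donor that leaves matters. Compound 3 therefore sets the anchor, and the expected step in this assay is a number 0.6 two-fold dilutions higher from compound 3 to compound 4 (within the scatter), close to no change or a slight weakening, since the remaining ring is of similar size. Compound 4 is estimated at 0.003 ug/mL, with a range expected from 0.001 ug/mL to 0.01 ug/mL.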

Compound 4, minimum inhibitory concentration: 0.01 ug/mL
Compound 4: middle estimate off by 1.7 two-fold dilutions, on the low side, and the stated range covers the measured number.
By their numbers in this assay, from the lowest: compound 3; then compounds 1, 2 and 4 (each within the scatter of the next).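

In this assay the exchange of one six-membered ring for another on a saturated chain carbon bound to a double-bonded chain carbon is not silent: the result is a number 2.3 two-fold dilutions higher from compound 3 to compound 4 (beyond the scatter), even though both groups have the same count of heavy atoms. The advantage of piperazin-1-yl over hydroxy and formyl does not carry over to piperidin-1-yl, with no change at the digits printed from compound 1 to compound 4 (within the scatter) and no change at the digits printed from compound 2 to compound 4 (within the scatter), so at this place a ring alone does not give the lower number. No available evidence explains the difference between the two rings.

The compounds shown do not separate the second ring nitrogen from the hydrogen-bond donor that leaves with it. As far as these compounds go, it also remains open how a 4-methylpiperazin-1-yl or morpholin-4-yl group would stand at this place.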